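Removing the chloro group from compound 2: what to expect

The source may hold more compounds than are shown below. What is called first, only, known or untested is meant among the compounds shown, and "the series" means these compounds.

The shared core carries a pyrimidine bearing a chain amide, and two compounds with this core have been tested in a functional assay on SK-MEL-28 cells (Homo sapiens) for cytotoxicity, read by MTT assay; on this read-out higher numbers stand for weaker inhibition and lower numbers for stronger inhibition. Compound 1 `O=C(NCCCNc1nccc(-c2c(-c3cccc(F)c3)nc3sccn23)n1)c1ccc(F)cc1` has the longer chain, and in this assay compound 1 gives only a limit of the assay, > 20000 nM. Compound 2 `O=C(NCCNc1nccc(-c2c(-c3cccc(F)c3)nc3sccn23)n1)c1ccc(Cl)cc1` has the shorter chain and a chloro group on the benzamide ring, and in this assay compound 2 gives 8160 nM, the only plain number shown, so compound 2 stands alone as the one measured value. Going by the values given here, the single step known, an at least 2.4-fold lower number from compound 1 to compound 2 (0.38 log units; beyond the scatter), changed two things at once and so speaks to the chain and the halogen together; it involves the limit of > 20000 nM in this assay, at which 1 of the 2 values shown sits, and is therefore only a lower bound.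

Compound 3 `O=C(NCCNc1nccc(-c2c(-c3cccc(F)c3)nc3sccn23)n1)c1ccccc1` differs from compound 2 by hydrogen in place of chloro on an aromatic carbon, on an aromatic carbon of the benzamide ring, para to a large group. Among the compounds with values here, no measured step isolates this change, so no direction beyond the scatter is expected, with only a slight lean toward weaker inhibition; the expected step is a 1.5-fold higher number from compound 2 to compound 3 (0.17 log units; within the scatter). Compound 3 is estimated at 12000 nM, between 4500 nM and 32000 nM.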

Compound 3, half-maximal inhibitory concentration: 17000 nM
For compound 3 the middle estimate is 1.4-fold (0.15 log units) below the measured one, within the range that was stated.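

Going by these compounds alone, this is the first step that isolates the chloro group on the benzamide ring. With the chain held the same in this assay, hydrogen in place of chloro on an aromatic carbon, para to a large group, gives a 2.1-fold higher number from compound 2 to compound 3 (0.32 log units; beyond the scatter). The earlier step changed the chain and the halogen together, whereas this one shows that a single chlorine atom at this position is enough on its own to move the number beyond the usual scatter, though only modestly. The other new step is an at least 1.1-fold lower number from compound 1 to compound 3 (0.07 log units; that floor lies within the scatter) and it rests on a limit of the assay, with a floor that lies within the scatter, so no direction can be read from it: the limit of > 20000 nM in this assay, at which 1 of the 3 values shown sits.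

The compounds shown leave open whether a bromo, methyl or methoxy group on this same carbon would match chloro, or whether any group there would lower the number further. They also leave open what the chain length does alone, which would take the same benzamide ring, such as the 4-chlorophenyl one, carried on the longer chain.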